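Changing the Aryl Group on the Nitrogen-Bearing Ring

A few compounds are considered here, and "the series" means these few. Any claim that something is new, unique, unknown or untested is made for them only; others in the source may bear on it.

Compound 1 `CCOC(=O)C1=Cc2ccccc2OC1(OCc1cn(-c2ccc(F)cc2)nn1)C(F)(F)F`: 8400 nM
Compound 2 `CCOC(=O)C1=Cc2ccccc2OC1(OCc1cc(-c2ccc(Br)cc2)no1)C(F)(F)F`: 52300 nM
Compound 3 `CCOC(=O)C1=Cc2ccccc2OC1(OCc1cc(-c2ccc(F)cc2F)no1)C(F)(F)F`: a limit, > 150000 nM

Of the compounds shown here, three sharing one core have been measured in a functional assay on HeLa cells (Homo sapiens) for inhibition, read by MTT assay, with a stated time of 24 h; a lower number here means a stronger inhibitor, a higher number a weaker inhibitor. Compound 1 gives the lowest of the two real numbers, and compound 2 gives the higher one. For the measured compounds named here, compound 3 is the single value sitting at the limit of > 150000 nM in this assay, at which 1 of the 3 values shown sits, so it yields no number, only a limit.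

Going by the values given here, the only measured step compares two aryl groups on the other five-membered ring: an at least 2.8-fold higher number from compound 2 to compound 3 (0.45 log units; beyond the scatter). That swap on an aromatic carbon weakened inhibition at least modestly.

Compound 4 `CCOC(=O)C1=Cc2ccccc2OC1(OCc1cn(-c2cccc(OC)c2)nn1)C(F)(F)F` is the unmeasured analogue of compound 1, differing in one place: 3-methoxyphenyl in place of 4-fluorophenyl on an aromatic nitrogen. Among the compounds with values here, the one measured step concerns a different ring and different groups, so it bears only loosely on this change, though it shows that such an aryl swap can cost potency. A small loss is therefore expected, with a 1.4-fold higher number from compound 1 to compound 4 (0.15 log units; within the scatter) as the estimated step. Compound 4 is estimated at 12000 nM in this assay, within a range from 4000 nM to 40000 nM.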

Compound 4, half-maximal inhibitory concentration: > 150000 nM
Compound 4 ended at the assay's limit; the forecaster's own chance of this, stated with the estimate: 5%; middle value at least 12-fold (1.09 log units) from the limit.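

In this assay, the aryl group on the aromatic nitrogen of the five-membered ring with 3 nitrogen proves highly sensitive, since 3-methoxyphenyl in place of 4-fluorophenyl gives an at least 17-fold higher number from compound 1 to compound 4 (1.25 log units; beyond the scatter). For the compounds shown here, the only earlier step concerned an aryl swap on a different five-membered ring, so this is the first sign that the aryl group on this ring also matters. The reading for compound 4 is a limit and not a number, so the true size of the loss stays unknown, and compound 4 is not alone there: the limit of > 150000 nM in this assay, at which 2 of the 4 values shown sit.

This single swap changes both the substituent and its place on the phenyl ring, so the compounds shown cannot separate those two changes; 3-fluorophenyl and 4-methoxyphenyl would be the direct tests. Also open, going by these compounds, is whether 4-chlorophenyl or 4-aminophenyl at this position would give a lower number than compound 1.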